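The compounds below may be only part of what the source reports. "The series", "measured", "known", "first", "only" and "open" are said of these compounds alone.

Measured so far:
compound 1, `Cn1cc(-c2nc3ccccc3n2C(=O)c2ccccc2)c2ccccc21`: 19600 nM
compound 2, `COc1ccccc1C(=O)n1c(-c2cn(C)c3ccccc23)nc2ccccc21`: 12300 nM
compound 3, `COc1ccc2c(c1)c(-c1nc3ccccc3n1C(=O)c1ccc(OC)c(OC)c1)cn2C`: 2700 nM

These three values come from a functional assay on A549 cells (Homo sapiens) for inhibition, read by MTT assay, with a stated time of 24 h; on this read-out lower numbers stand for stronger inhibition of growth and higher numbers for weaker inhibition of growth. Compound 1 and compound 2 share a core and differ by methoxy in place of hydrogen on an aromatic carbon, a change that gave a 1.6-fold lower number from compound 1 to compound 2 (0.20 log units; within the scatter). Compound 3 carries a different core; how the two cores differ is not broken down here. Its value is the lowest of the three, and both of the others lie beyond the scatter from it.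

Compound 4, `COc1ccc2c(c1)c(-c1nc3ccccc3n1C(=O)c1cc(OC)c(OC)c(OC)c1)cn2C`, is not yet measured. It differs from compound 3 by methoxy in place of hydrogen on an aromatic carbon. Among the compounds with values here, this is the same kind of change as the one between compound 1 and compound 2, though the surroundings differ: there the new group sat ortho to a large group, here it sits ortho to a methoxy group, meta to a large group and meta to a methoxy group. Since that earlier step stayed within the scatter, compound 4 is expected to move from compound 3 by a 1.4-fold lower number from compound 3 to compound 4 (0.13 log units; within the scatter). In this assay compound 4 is therefore estimated at 2000 nM, most likely between 700 nM and 5500 nM.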

Compound 4, concentration for 50% growth inhibition: 2400 nM
Estimate against measurement, compound 4: 1.2-fold (0.08 log units) below; the range from low to high includes it.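

In this assay, methoxy in place of hydrogen on an aromatic carbon gave a 1.1-fold lower number from compound 3 to compound 4 (0.05 log units; within the scatter), so the step stays small on this core as well. Set beside the earlier step, the change looks the same on both cores, with no difference that can be told apart: the same change on two cores in this assay, a 1.6-fold lower number (0.20 log units; within the scatter) from compound 1 to compound 2 and a 1.1-fold lower number (0.05 log units; within the scatter) from compound 3 to compound 4, 1.4-fold (0.15 log units) apart, within the scatter of two such steps. This supports carrying the change between these two cores only, and the new group sits in different surroundings in each pair, so it does not show that the change would stay this small on another core or at another place.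

The compounds shown leave open whether a different group at these places, such as an amine, a carboxylic acid or a longer alkoxy chain, would shift the number further.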